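Triazole substituent swap on the shared core

The source may report more compounds than this note shows. Statements on the series, on what has been measured and on what is new or still open speak of the compounds shown alone.

Two compounds of the series have numbers in a functional assay on MCF7 cells (Homo sapiens) for antiproliferative activity, read by MTT assay, with a stated time of 72 h; a higher number here means a weaker inhibitor, a lower number a stronger inhibitor. Compound 1 `O=C1O[C@H]([C@@H](O)Cn2cc(-c3cccc(O)c3)nn2)C(OCc2ccccc2)=C1OCc1ccccc1` gives 51800 nM. Compound 2 `O=C1O[C@H]([C@@H](O)Cn2cc(CCO)nn2)C(OCc2ccccc2)=C1OCc1ccccc1` gives 63400 nM in this assay. For the measured compounds named here, compound 2 thus sits alongside compound 1, the two numbers lying within the usual scatter of each other; the single measured step, a 1.2-fold higher number from compound 1 to compound 2 (0.09 log units; within the scatter), is too small to read as a change.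

Compound 3 `O=C1O[C@H]([C@@H](O)Cn2cc(C3CC3)nn2)C(OCc2ccccc2)=C1OCc1ccccc1` is not yet measured. It differs from compound 2 by cyclopropyl in place of 2-hydroxyethyl on an aromatic carbon. Going by the values given here, no measured step covers this particular change. Among the compounds with values here, the one step available, from compound 1 to compound 2, puts 2-hydroxyethyl in place of 3-hydroxyphenyl at the same aromatic carbon and stays within the scatter; nothing measured touches cyclopropyl. Given that the only recorded swap at this position left this assay flat, the expectation is a 1.2-fold lower number from compound 2 to compound 3 (0.06 log units; within the scatter), a step inside the scatter with no set direction. The estimate for compound 3 in this assay is 55000 nM, with a range of 20000 nM to 150000 nM.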

Compound 3, half-maximal inhibitory concentration: 25900 nM
Compound 3: middle estimate off by 2.1-fold (0.33 log units), on the high side; the measured number falls inside the stated range.
By their numbers in this assay, from the lowest: compounds 3, 1 and 2 (each within the scatter of the next, the first and the last beyond it).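

Compound 3 gives this aromatic carbon its first measurable effect in this assay: cyclopropyl in place of 2-hydroxyethyl produces a 2.4-fold lower number from compound 2 to compound 3 (0.39 log units; beyond the scatter), whereas the earlier swap at this position stayed flat. The comparison with the aryl-bearing compound is less clear, since cyclopropyl in place of 3-hydroxyphenyl gives a 2.0-fold lower number from compound 1 to compound 3 (0.30 log units; within the scatter), so compound 3 separates from compound 2 but not from compound 1, and the position tolerates change without a clean order across all three groups. Nothing available accounts for the step between the two three-heavy-atom groups, which differ in the ring and in the hydrogen-bond donor and acceptor counted on 2-hydroxyethyl.

The compounds shown do not separate the presence of the ring from the absence of the hydroxyl, a question that a plain ethyl group at this carbon would address directly. Also open, as far as these compounds go, is how this position responds to an amine such as 2-aminoethyl, a carboxylic acid, a longer chain such as 3-hydroxypropyl, or an unsubstituted phenyl.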